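The compounds below may be only part of what the source reports. "The series", "measured", "known", "first", "only" and "open" are said of these compounds alone.

Measured so far in an assay on isolated protein for inhibition of Voltage-dependent L-type calcium channel subunit alpha-1C (Cavia porcellus); on this read-out lower numbers stand for stronger inhibition and higher numbers for weaker inhibition:

compound 1, `CCOC(=O)C1=C(C)NC(C)=C(C(=O)OCC)C1c1[nH]cnc1Cl`: 437 nM
compound 2, `COC(=O)C1=C(C)NC(C)=C(C(=O)OC(C)(C)C)C1c1[nH]cnc1Cl`: 1860 nM
compound 3, `COC(=O)C1=C(C)NC(C)=C(C(=O)OCC2CCCCC2)C1c1[nH]cnc1Cl`: 355 nM

Compound 3 gives the lowest number of the three, but compound 1 sits within the scatter of it, so the two cannot be told apart; compound 2 stands clearly higher. Within the data shown here, the one change for which a step is known is a 5.2-fold lower number from compound 2 to compound 3 (0.72 log units; beyond the scatter), a modest gain that concerns the larger ester group.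

Compound 4, `CCOC(=O)C1=C(C)NC(C)=C(C(=O)OCC2CCCCC2)C1c1[nH]cnc1Cl`, differs from compound 3 in a single spot: methyl in place of hydrogen on a saturated chain carbon bound to an oxygen next to a carbonyl group. Among the measured compounds shown here, no measured step covers this particular change. The closest hint comes from compound 1, which carries ethyl on both ester oxygens and gives 437 nM, a number within the scatter of compound 3, so the length of the smaller ester alkyl has not shown a clear effect among the compounds measured here. The expectation is therefore a step of a 1.1-fold lower number from compound 3 to compound 4 (0.05 log units; within the scatter), that is nothing beyond the scatter, in this assay. Compound 4 is accordingly estimated at 320 nM, within a range of 130 nM to 800 nM.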

Compound 4, half-maximal inhibitory concentration: 513 nM
For compound 4 the middle estimate is 1.6-fold (0.20 log units) below the measured one; the measured number falls inside the stated range.
By their numbers in this assay, from the lowest: compounds 3, 1 and 4 (each within the scatter of the next); then compound 2.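

In this assay, among these compounds, methyl in place of hydrogen on a saturated chain carbon bound to an oxygen next to a carbonyl group, which turns a methyl ester into an ethyl ester while cyclohexylmethyl stays on the other ester, gives the first direct reading of this spot (a 1.4-fold higher number from compound 3 to compound 4 (0.16 log units; within the scatter)), and that step cannot be told from repeat-measurement noise. The second new pair holds the ethyl ester fixed and swaps the other ester from ethyl to cyclohexylmethyl (a 1.2-fold higher number from compound 1 to compound 4 (0.07 log units; within the scatter)), and this much bigger change in group size also stays inside the noise, so neither edit separates the compounds it connects. Nothing measured here offers an explanation for either result.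

As far as these compounds go, whether a longer chain such as propyl or butyl on the smaller ester would keep the number in the same place remains open, since only methyl and ethyl appear there. An amine or a carboxylic acid at the end of the larger ester chain also remains untested among these compounds, so the tolerance seen here covers only plain carbon groups.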